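A few compounds are considered here, and "the series" means these few. Any claim that something is new, unique, unknown or untested is made for them only; others in the source may bear on it.

Of the compounds shown here, two have been measured in an assay on isolated protein for binding affinity to histamine H2 receptor (Homo sapiens); a higher number here means a weaker inhibitor, a lower number a stronger inhibitor. Compound 1 (`CCCCCC(=O)c1ccc(OCCCN2CCNCC2)cc1`) gives 14500 nM in this assay. Compound 2 (`CCCCCCCCC(=O)c1ccc(OCCCN2CCN(C(=O)OCC)CC2)cc1`) gives 2690 nM in this assay, the lower of the two numbers, and the gap between compound 1 and compound 2 lies beyond the usual scatter. The two compounds differ in more than one place, so no single step can be read from them.

Compound 3 (`C=C(C)C(=O)c1ccc(OCCCN2CCN(C(=O)OCC)CC2)cc1`) has not yet been measured. Compared with compound 2, the change is 1-methylethenyl in place of octyl on a carbonyl carbon. Within the data shown here, no measured pair isolates what a shorter group on this carbonyl carbon does, and compound 1, the only other point, also carries a different group on the piperazine. Still, the shorter chain of compound 1 goes with 14500 nM against compound 2 with 2690 nM, which points toward a higher number for compound 3. In this assay the estimated step is a 3.7-fold higher number from compound 2 to compound 3 (0.57 log units; beyond the scatter), a move toward weaker binding, beyond the scatter. Compound 3 is expected to give 10000 nM in this assay, within a range from 3000 nM to 40000 nM.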

Compound 3, inhibition constant: 22400 nM
Estimate against measurement, compound 3: 2.2-fold (0.35 log units) below, within the range that was stated.
By their numbers in this assay, from the lowest: compound 2; then compounds 1 and 3 (each within the scatter of the next).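

In this assay, among these compounds, the change from octyl to 1-methylethenyl on the carbonyl carbon gives an 8.3-fold higher number from compound 2 to compound 3 (0.92 log units; beyond the scatter) and provides the first reading at this position with the rest of the molecule held constant. The earlier pair could not show this, since compound 1 and compound 2 differ in more than one place; here the shift to the higher number belongs to this single exchange of groups, and the octyl chain is the better of the two at this carbonyl carbon. No measurement shown accounts for the size of this step or identifies which feature of the exchange produces it.

The exchange removes a long chain and introduces a double bond in one move, so the compounds shown leave the contributions of chain length and unsaturation unseparated; an isopropyl group on the same carbonyl carbon would divide the two. They also leave open how the number moves along a series of straight chains with the rest of compound 2 kept in place, such as a butyl, a hexyl or a decyl chain, and so whether octyl lies near the best length.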